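Fluoro on the Pendant Phenyl, Tried a Second Time

The source may hold more compounds than are shown below. What is called first, only, known or untested is meant among the compounds shown, and "the series" means these compounds.

Compound 1 `CC(=O)c1cc(-c2ccc(F)cc2)cc2cc(-c3ccccc3)[nH]c12`: 36.4%
Compound 2 `CC(=O)c1cc(-c2ccc(F)cc2)cc2cc(-c3ccc(F)cc3)[nH]c12`: 20%
Compound 3 `CC(=O)c1cc(/C=C/c2ccccc2)cc2cc(-c3ccccc3)[nH]c12`: 34.1%

Three compounds on a shared core were tested in a functional assay on MCF7 cells (Homo sapiens) for cytotoxicity, read by MTT assay, with a stated time of 2 days, tested at 100 uM; a lower number here means a stronger effect, a higher number a weaker effect of the compound at the concentration tested. Compound 1 gives 36.4% there, and compound 2 gives 20%. The two differ by fluoro in place of hydrogen on an aromatic carbon, and that change made a step of a number 16.4 percentage points lower from compound 1 to compound 2 (beyond the scatter).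

Compound 3 carries a different group on the core: 2-phenylethenyl in place of 4-fluorophenyl on an aromatic carbon. Against compound 1 this gave a step of a number 2.3 percentage points lower from compound 1 to compound 3 (within the scatter), so compound 1 and compound 3 cannot be told apart.

Compound 4 `CC(=O)c1cc(/C=C/c2ccc(F)cc2)cc2cc(-c3ccccc3)[nH]c12` is not yet measured. It stands to compound 3 as compound 2 stands to compound 1, through (fluoro in place of hydrogen on an aromatic carbon); the place is the same, and the change is the same, while the two cores differ as told by 2-phenylethenyl in place of 4-fluorophenyl on an aromatic carbon.

Compound 4 is expected to sit at 24% in this assay, between 10% and 38%. This estimate means a step of a number 10.1 percentage points lower from compound 3 to compound 4 (beyond the scatter). The expectation rests on compound 1 and compound 2, because a number 16.4 percentage points lower from compound 1 to compound 2 (beyond the scatter) shows what the change did once; a somewhat smaller step is assumed, since a single case is known.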

Compound 4, a percentage reported as activity, at one concentration (the size of the read-out at that concentration, not a potency): 46.7%
Compound 4: the middle estimate sits 22.7 percentage points below what was measured; the whole stated range lies below it.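

In this assay, fluoro in place of hydrogen did not carry over from one core to the other, and the two steps run in opposite directions: the same change on two cores in this assay, a number 16.4 percentage points lower (beyond the scatter) from compound 1 to compound 2 and a number 12.6 percentage points higher (beyond the scatter) from compound 3 to compound 4, 29 percentage points apart, beyond the scatter of two such steps On the core of compound 3 the change gave a number 12.6 percentage points higher from compound 3 to compound 4 (beyond the scatter), and setting 2-(4-fluorophenyl)ethenyl in place of 4-fluorophenyl gave a number 10.3 percentage points higher from compound 1 to compound 4 (beyond the scatter). This shows that the effect of the fluoro in this series depends on the core it is placed on, but with one pair per core it does not show what lies behind the reversal or what the change would do on a third core.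

The compounds shown leave open whether a chloro or a methoxy group in place of that fluoro would follow the step to compound 2 or the step to compound 4. They also leave open whether an amine or a carboxylic acid on the same ring would give a number lower or higher than these.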